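The source may report more compounds than this note shows. Statements on the series, on what has been measured and on what is new or still open speak of the compounds shown alone.

Working notes on the series.

Compound 1 `Cc1ccc(-c2ccc(C(=O)Nc3ccc(Oc4ccnc5[nH]ccc45)cc3)nc2)cc1` reaches only a limit in a functional assay on A549 cells (Homo sapiens) for cytotoxicity, read by MTT assay, with a stated time of 72 h (on this read-out higher numbers stand for weaker inhibition and lower numbers for stronger inhibition), shown as > 10000 nM. Compound 2 `COc1ccc(-c2ccc(C(=O)Nc3ccc(Oc4ccnc5[nH]ccc45)cc3)nc2)cc1` likewise gives a limit in this assay, > 10000 nM. Compound 3 `Cc1ccc(-c2ccc(C(=O)Nc3ccc(Oc4ccnc5[nH]ccc45)c(F)c3)nc2)cc1` gives a number in this assay, 2300 nM. The core of compound 3 differs from that of compound 1 by fluoro in place of hydrogen on an aromatic carbon, and the step is an at least 4.3-fold lower number from compound 1 to compound 3 (0.63 log units; beyond the scatter). The change from compound 1 to compound 2 is methoxy in place of methyl on an aromatic carbon, and its step is a step that the two limits leave unreadable from compound 1 to compound 2; both values sit at the limit of > 10000 nM in this assay, at which 2 of the 3 values shown sit, so its size cannot be read.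

Compound 4 `COc1ccc(-c2ccc(C(=O)Nc3ccc(Oc4ccnc5[nH]ccc45)c(F)c3)nc2)cc1` carries the same change, (methoxy in place of methyl on an aromatic carbon), now on the core of compound 3. With the earlier step unreadable, a small step is expected from compound 3 to compound 4 in this assay, a 1.3-fold higher number from compound 3 to compound 4 (0.12 log units; within the scatter), resting on compound 3 at 2300 nM. Compound 4 is estimated at 3000 nM, expected between 1200 nM and 9000 nM.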

Compound 4, half-maximal inhibitory concentration: 2240 nM
For compound 4 the middle estimate is 1.3-fold (0.13 log units) above the measured one; low and high end bracket the measured number.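

In this assay, methoxy in place of methyl on the fluoro-bearing core gives a 1.0-fold lower number from compound 3 to compound 4 (0.01 log units; within the scatter), so the two compounds cannot be told apart on this core. Fluoro in place of hydrogen gives an at least 4.4-fold lower number from compound 2 to compound 4 (0.64 log units; beyond the scatter), which agrees in direction with the step on the methyl-bearing pair, but neither size is fixed: the same change on two cores in this assay, an at least 4.3-fold lower number (0.63 log units; beyond the scatter) from compound 1 to compound 3 and an at least 4.4-fold lower number (0.64 log units; beyond the scatter) from compound 2 to compound 4; the limit leaves it open whether they differ Whether the methoxy change carries across from one core to the other is not shown, as its step on the core without fluoro cannot be read: the limit of > 10000 nM in this assay, at which 2 of the 4 values shown sit.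

The compounds shown leave open how the number responds to an amine, a carboxylic acid or a longer chain in place of the methyl or methoxy. They also leave open whether chloro in place of the fluoro would give a similar step.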